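A few compounds are considered here, and "the series" means these few. Any claim that something is new, unique, unknown or untested is made for them only; others in the source may bear on it.

Working notes on the series in a functional assay on MCF7 cells (Homo sapiens) for inhibition, read by radiometric assay and XTT assay; on this read-out lower numbers stand for stronger inhibition and higher numbers for weaker inhibition. Compound 1 `CCCC/C=C/C=C/[C@@]1(C)SC(O)=CC1=O` gives 60 ug/mL, and compound 2 `CCCCCCCC[C@@]1(C)SC(=O)C=C1OCC(=O)O` gives 50.3 ug/mL, within the scatter of compound 1. Compound 3 `CCCCCC[C@@]1(C)SC(=O)C=C1OCC(=O)NCCCBr` gives 21 ug/mL, a number lower than that of compound 2 by more than the scatter. Compound 4 `CCCCCCCC[C@@]1(C)SC(=O)C=C1OC(=O)OCC` has ethoxycarbonyl in place of carboxymethyl on an oxygen on an unsaturated carbon, relative to compound 2: ethoxycarbonyl in place of carboxymethyl on an oxygen on an unsaturated carbon. Going by the values given here, no measured pair isolates this change, so the expectation rests on the narrow spread of the series, from compound 3 at 21 ug/mL to compound 1 at 60 ug/mL. A step within the scatter is expected, with no firm direction. The estimated step is a 1.3-fold lower number from compound 2 to compound 4 (0.10 log units; within the scatter). The expected value for compound 4 is 40 ug/mL, with an estimated range of 18 ug/mL to 90 ug/mL.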

Compound 4, half-maximal inhibitory concentration: 15.1 ug/mL
Compound 4: the middle estimate sits 2.6-fold (0.42 log units) above what was measured; the whole stated range lies above it.
By their numbers in this assay, from the lowest: compounds 4 and 3 (each within the scatter of the next); then compounds 2 and 1 (each within the scatter of the next).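

In this assay, going by these compounds alone, the oxygen on an unsaturated carbon responds to its substituent: ethoxycarbonyl in place of carboxymethyl gives the only single-change step (a 3.3-fold lower number from compound 2 to compound 4 (0.52 log units; beyond the scatter)), and it lies beyond the scatter. The change replaces a group carrying a hydrogen-bond donor with one carrying none, but a single pair cannot link that difference to the step. No measurement here bears on its origin.

Still open, from the compounds shown here alone, is whether an acetyl or a methoxycarbonyl on the same oxygen would track with ethoxycarbonyl. Also open, going by these compounds, is whether the step holds on a shorter chain or with the dienyl chain of compound 1.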